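Aryl Swap on the Cyclopropane Amide of Compound 3

The source may hold more compounds than are shown below. What is called first, only, known or untested is meant among the compounds shown, and "the series" means these compounds.

Measured so far:
compound 1 `CCC(CC)C(N)CCN(C(=O)[C@@H]1C[C@H]1c1ccccc1)c1ccc(-c2ccccc2)cc1` — 2 nM
compound 2 `O=C([C@@H]1C[C@H]1c1ccccc1)N(CCNCC1CCCCC1)c1ccc(-c2ccccc2)cc1` — 6.6 nM
compound 3 `CC[C@H](C)[C@H](N)CN(C(=O)[C@@H]1C[C@H]1c1ccc(Cl)cc1)c1ccc(-c2ccccc2)cc1` — 4300 nM

In a functional assay for agonist activity at G protein-coupled receptor 88 (Homo sapiens), read by HTRF and cAMP accumulation (on this read-out lower numbers stand for an effect already at smaller amounts and higher numbers for an effect only at larger amounts of compound), compound 1 gives 2 nM, and compound 2 gives 6.6 nM. Among the measured compounds shown here, the only single-point step among the measured compounds is a 3.3-fold higher number from compound 1 to compound 2 (0.52 log units; beyond the scatter), which concerns the amine-bearing chain rather than the aryl group on the three-membered ring. Compound 3 stands at the high end of the three numbers shown, with 4300 nM, far from both compound 1 and compound 2; it differs from them in more than one place, so no single step accounts for its position.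

Compound 4 `CC[C@H](C)[C@H](N)CN(C(=O)[C@@H]1C[C@H]1c1cccc(C#N)c1)c1ccc(-c2ccccc2)cc1` is the next compound, differing from compound 3 only in 3-cyanophenyl in place of 4-chlorophenyl on a saturated ring carbon. For the measured compounds named here, no measured step touches this aryl group, so there is no precedent here for the size or direction of the change. The expectation is therefore a step of a 1.2-fold lower number from compound 3 to compound 4 (0.09 log units; within the scatter), close to no change beyond the scatter. Compound 4 is estimated at 3500 nM, within a range from 800 nM to 15000 nM.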

Compound 4, half-maximal effective concentration: 1600 nM
For compound 4 the middle estimate is 2.2-fold (0.34 log units) above the measured one, and the stated range covers the measured number.
By their numbers in this assay, from the lowest: compound 1; then compound 2; then compound 4; then compound 3.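

In this assay, among the compounds shown here, the aryl group on the cyclopropane proves able to shift the number: 3-cyanophenyl in place of 4-chlorophenyl gives a 2.7-fold lower number from compound 3 to compound 4 (0.43 log units; beyond the scatter) as a modest step, the only one at this position so far. The swap changes both the group on the phenyl ring and its place on that ring, so this single step cannot be divided between the two. Nothing available explains the step or ties it to any property of either group.

The compounds shown leave open whether 3-chlorophenyl or 4-cyanophenyl would separate those two parts of the change, and what a methoxy group or a fluorine on the same ring would do. They also leave open whether 3-cyanophenyl would move the number similarly on the amine-bearing chain of compound 1.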